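This account rests on a few compounds, and the source may have more. Where it says the series, first, only, none or still open, it means among the compounds named here.

Measured so far:
- compound 1, `C#Cc1cn([C@@H]2O[C@H](CO)[C@@H](O)[C@H]2O)c2ncnc(OC)c12`: 12700 nM
- compound 2, `Nc1nc(N)c2c(-c3ccoc3)cn([C@@H]3O[C@H](CO)[C@@H](O)[C@H]3O)c2n1`: > 20000 nM

Among the measured compounds shown here, compound 1 is the only compound of the two with a numerical result in a functional assay on HepG2 cells (Homo sapiens) for antiproliferative activity, read by XTT assay, with a stated time of 72 h; a lower number here means a stronger inhibitor, a higher number a weaker inhibitor. In this assay compound 1 gives 12700 nM, a weak effect. Compound 2 gives only a limit in this assay, > 20000 nM, so no number is known for it; the limit is the limit of > 20000 nM in this assay, at which 1 of the 2 values shown sits. Compound 2 differs from compound 1 in more than one place. For the measured compounds named here, no single step between them can be read.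

Compound 3, `COc1ncnc2c1c(-c1ccco1)cn2[C@@H]1O[C@H](CO)[C@@H](O)[C@H]1O`, is not yet measured. It differs from compound 1 in one place: furan-2-yl in place of ethynyl on an aromatic carbon. Going by the values given here, compound 1 sits at the weak end of what this assay resolves, and no measured step shows how such a change behaves here, so the expectation rests on compound 1 alone. The step from compound 1 to compound 3 is expected to be small, a 1.2-fold higher number from compound 1 to compound 3 (0.07 log units; within the scatter), not clearly beyond the scatter in either direction. Compound 3 is therefore estimated at 15000 nM in this assay, within a range from 5000 nM to 40000 nM.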

Compound 3, half-maximal inhibitory concentration: 300 nM
Beside the measured number, compound 3's estimate is 50-fold (1.70 log units) above it; the measured number lies below the stated range.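

In this assay, furan-2-yl in place of ethynyl on an aromatic carbon gives a 42-fold lower number from compound 1 to compound 3 (1.63 log units; beyond the scatter), so what sits at this carbon, two ring bonds from the ring nitrogen, can strongly change the result in these cells. Among the compounds shown here, this is the first single change that can be read here, as compound 2 differs from compound 1 in more than one place. The change swaps a group of 2 heavy atoms with a triple bond for a five-membered aromatic ring of 5 heavy atoms with one hydrogen-bond acceptor, and nothing measured here separates these differences or gives a cause for the step.

The compounds shown leave open whether the gain belongs to having an aromatic ring at this carbon or to the ring oxygen of furan-2-yl, a question that phenyl or thiophen-2-yl in the same place would bear on. Also open, from the compounds shown here alone, is whether the step would keep its size if an amine took the place of the methoxy group on the shared core, since this is a single pair of compounds.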